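Adding a Methyl to a Long-Lived Compound

The compounds below may be only part of what the source reports. "The series", "measured", "known", "first", "only" and "open" are said of these compounds alone.

In an in vitro ADME assay on microsomes from liver (Homo sapiens) for metabolic stability (on this read-out higher numbers stand for a longer-lived compound and lower numbers for a shorter-lived compound), compound 2 `CCc1nn(CCN)c(CC)c1Oc1cccc(C#N)c1` gives > 2 h, which is a limit of the assay and not a number. Compound 1 `CCc1nn(CCO)c(CC)c1Oc1cc(C)cc(C#N)c1` gives 0.283 h in this assay. Compound 3 `CCc1nn(CCN)c(CC)c1Oc1cc(C)cc(C#N)c1` is compound 2 with one change, methyl in place of hydrogen on an aromatic carbon. Among the measured compounds shown here, no measured pair shows this change alone, so its size is uncertain. For the measured compounds named here, with compound 1 at 0.283 h as the only guide, a modest shortening is expected, possibly no larger than the scatter. The expected step is an at least 1.3-fold lower number from compound 2 to compound 3 (0.12 log units; that floor lies within the scatter). Compound 3 is expected at 1.5 h, with an estimated range of 0.6 h to 3 h.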

Compound 3, half-life in the Homo sapiens assay: > 2 h
Compound 3 gave a limit, no number; the forecaster's own chance of this, stated with the estimate: 35%; middle value at least 1.3-fold (0.12 log units) from the limit.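

Compound 3 gives > 2 h in the Homo sapiens assay, which is a limit of the assay and not a number. Compound 2 gives > 2 h in the Homo sapiens assay, which is also a limit of the assay and not a number. The step for the added methyl therefore cannot be read: the limit of > 2 h in the Homo sapiens assay, at which 2 of the 3 values shown sit. New here is that a compound carrying this methyl can stay long-lived, since with the methyl in both compounds, amino in place of hydroxy gives an at least 7.0-fold higher number from compound 1 to compound 3 (0.84 log units; beyond the scatter). In a physicochemical assay for lipophilicity (a higher number here means a more lipophilic compound, a lower number a more polar compound), compound 2 gives 1.2 and compound 3 gives 1.5. In the physicochemical assay the same methyl gives a number 0.30 log units higher from compound 2 to compound 3 (within the scatter). Still open, from the compounds shown here alone, is whether the methyl changes the half-life at all in the Homo sapiens assay, and whether a methoxy group at this place would give a number rather than a limit.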